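The source may hold more compounds than are shown below. What is called first, only, known or untested is meant among the compounds shown, and "the series" means these compounds.

Working notes on the series.

Two members of the series carry a measurement in a functional assay on HepG2 cells (Homo sapiens) for cytotoxicity, read by MTT assay, with a stated time of 72 h (on this read-out lower numbers stand for stronger inhibition and higher numbers for weaker inhibition), so far. Compound 1 `CN1[C@@H]2c3[nH]c4ccccc4c3C[C@H]1[C@H](C#N)N1[C@@H](CNC(=O)c3ccc4ccccc4c3)c3[nH]c4ccccc4c3C[C@@H]21` gives 1210 nM in this assay, and compound 2 `CN1[C@@H]2c3[nH]c4ccccc4c3C[C@H]1[C@H](C#N)N1[C@@H](CNC(=O)c3cc4ccccc4o3)c3[nH]c4ccccc4c3C[C@@H]21` gives 280 nM. Among the measured compounds shown here, the one step between them, a 4.3-fold lower number from compound 1 to compound 2 (0.64 log units; beyond the scatter), leaves compound 2 with the lowest of the two numbers in this assay, with compound 1 as its nearest neighbour.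

Compound 3 `CN1[C@@H]2c3[nH]c4ccccc4c3C[C@H]1[C@H](C#N)N1[C@@H](CNC(=O)/C=C/c3ccccc3)c3[nH]c4ccccc4c3C[C@@H]21` is the next member awaiting its number. Its difference from compound 2 is 2-phenylethenyl in place of 1-benzofuran-2-yl on a carbonyl carbon. For the measured compounds named here, the only measured step in this assay, a 4.3-fold lower number from compound 1 to compound 2 (0.64 log units; beyond the scatter), exchanges one bicyclic aromatic group for another on the same carbonyl carbon and is of modest size. Going by the values given here, no measured step speaks directly to the entry of the 2-phenylethenyl group, so the direction of the change for compound 3 cannot be read from the data, and the expectation is a step of no more than the size already seen, in either direction.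

For compound 3 the estimated value in this assay is 600 nM, with a range from 200 nM to 2000 nM. This estimate corresponds to an expected step of a 2.1-fold higher number from compound 2 to compound 3 (0.33 log units; beyond the scatter).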

Compound 3, half-maximal inhibitory concentration: 470 nM
Compound 3: the middle estimate sits 1.3-fold (0.11 log units) above what was measured, within the range that was stated.
By their numbers in this assay, from the lowest: compounds 2 and 3 (each within the scatter of the next); then compound 1.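

In this assay, the step of a 1.7-fold higher number from compound 2 to compound 3 (0.22 log units; within the scatter) shows that the bicyclic 1-benzofuran-2-yl group is not needed on this carbonyl carbon to hold a number in this range: 2-phenylethenyl, with one aromatic ring, a double bond outside aromatic rings and no ring oxygen, stands level with it. The step of a 2.6-fold lower number from compound 1 to compound 3 (0.41 log units; beyond the scatter) is beyond the scatter, as is the earlier step of a 4.3-fold lower number from compound 1 to compound 2 (0.64 log units; beyond the scatter), so among these three compounds naphthalen-2-yl is the group that stands apart, and an all-carbon group as such does not account for the higher number, since 2-phenylethenyl also contains only carbon. No supporting measurement bears on these differences, so the data give no explanation for them.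

Still open, from the compounds shown here alone, is what this carbonyl carbon allows beyond aromatic groups, for example a plain phenyl group, a saturated cyclohexyl ring, or a longer chain ending in an amine or a carboxylic acid. Also open, going by these compounds, is whether compound 2 and compound 3 stay this close in any read-out other than this assay and on cells other than those used there.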